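Inverting both stereocentres of compound 1: expected oral exposure

The source may hold more compounds than are shown below. What is called first, only, known or untested is meant among the compounds shown, and "the series" means these compounds.

In an ADME assay on the whole organism for pharmacokinetics, with Rattus norvegicus as the target, at a dose of 5 mg/kg by the oral route (on this read-out higher numbers stand for higher exposure at the dose given and lower numbers for lower exposure), compound 1 `CO[C@H]1CC[C@@H](N2CC(=O)Nc3ncc(-c4ccc(C(C)(C)O)nc4)nc32)CC1` gives 2770 nM and compound 2 `CO[C@H]1CC[C@H](N2C(=O)CNc3ncc(-c4ccc(C(C)(C)O)nc4)nc32)CC1` gives 2900 nM. Among the measured compounds shown here, these two values lie within the scatter of each other, so compound 1 stands level with the only other number available. Compound 3 `CO[C@H]1CC[C@H](N2CC(=O)Nc3ncc(-c4ccc(C(C)(C)O)nc4)nc32)CC1` has the same atoms and bonds as compound 1 and differs only in configuration as drawn (the two compounds have the same atoms and bonds and differ only in configuration as drawn: 2 of 2 stereo elements differ (all stereocentres are inverted: mirror images); a stereocentre at a saturated ring carbon is drawn s in compound 1 and r in compound 3; a stereocentre at a saturated ring carbon is drawn s in compound 1 and r in compound 3). Nothing leaves and nothing enters, and all stereocentres are inverted. For the measured compounds named here, no measured pair shows a change of this kind, so the data offer no direction for it. Going by the values given here, the only anchor is compound 1 at 2770 nM, and no step beyond the scatter is expected. The expected 1.1-fold lower number from compound 1 to compound 3 (0.03 log units; within the scatter) is therefore a small one, with wide uncertainty. For compound 3 the estimate is 2600 nM, with an expected range from 900 nM to 6500 nM.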

Compound 3, maximal plasma concentration: 6300 nM
Compound 3: middle estimate off by 2.4-fold (0.38 log units), on the low side; low and high end bracket the measured number.
By their numbers in this assay, from the lowest: compounds 1 and 2 (each within the scatter of the next); then compound 3.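

In this assay, among the compounds shown here, inverting both stereocentres gives a 2.3-fold higher number from compound 1 to compound 3 (0.36 log units; beyond the scatter), the first step that lies beyond the scatter. Configuration at these saturated ring carbons therefore counts on this read-out, although the step is modest and rests on a single pair. Nothing leaves or enters, so the step can be assigned to stereochemistry alone: the fact that compounds 1 and 3 differ only in the configuration as drawn

The compounds shown leave open whether one stereocentre or both together carry the step, since the two are inverted at once in this pair. Also open, as far as these compounds go, is whether the same inversion gives a step of like size and direction with another group, such as a carboxylic acid or an amine, in place of the methoxy group.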